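From (Piperidin-1-yl)methyl to 4-Fluorophenyl on the Shared Core

The source may hold more compounds than are shown below. What is called first, only, known or untested is meant among the compounds shown, and "the series" means these compounds.

In a functional assay on HeLa cells (Homo sapiens) for cytotoxicity, read by sulforhodamine B assay, with a stated time of 72 h (a lower number here means a stronger inhibitor, a higher number a weaker inhibitor), compound 1 (`C=C1C(=O)O[C@@H]2CC(C)=C([C@@H](C)CCCOC(C)=O)[C@@H](OC(=O)CN3CCCCC3)[C@H]12`) gives 10300 nM as its reading. Compound 3 (`C=C1C(=O)O[C@@H]2CC(C)=C([C@@H](C)CCCOC(C)=O)[C@@H](OC(=O)c3cccc(F)c3)[C@H]12`) gives 11800 nM and compound 2 (`C=C1C(=O)O[C@@H]2CC(C)=C([C@@H](C)CCCOC(C)=O)[C@@H](OC(=O)COc3cccc4[nH]nnc34)[C@H]12`) gives 23000 nM as theirs. The gap is a 1.1-fold higher number from compound 1 to compound 3 (0.06 log units; within the scatter) on one side, which leaves those two level, and a 2.2-fold higher number from compound 1 to compound 2 (0.35 log units; beyond the scatter) on the other, a modest separation. Compound 4 (`C=C1C(=O)O[C@@H]2CC(C)=C([C@@H](C)CCCOC(C)=O)[C@@H](OC(=O)c3ccc(F)cc3)[C@H]12`) is still unmeasured, and its difference is 4-fluorophenyl in place of (piperidin-1-yl)methyl on a carbonyl carbon with 4-fluorophenyl in place of (piperidin-1-yl)methyl on a carbonyl carbon. The closest guide is the exchange to 3-fluorophenyl in compound 3, a step of a 1.1-fold higher number from compound 1 to compound 3 (0.06 log units; within the scatter) in size. The step of a 1.9-fold lower number from compound 2 to compound 3 (0.29 log units; within the scatter) also stays small. No step beyond the scatter is therefore expected in this assay here. An estimated 1.2-fold higher number from compound 1 to compound 4 (0.07 log units; within the scatter) is expected. Compound 4 is estimated at 12000 nM (expected range 6500 nM to 22000 nM).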

Compound 4, half-maximal inhibitory concentration: 12000 nM
Beside the measured number, compound 4's estimate shows no gap at the digits printed, within the range that was stated.
By their numbers in this assay, from the lowest: compounds 1, 3, 4 and 2 (each within the scatter of the next, the first and the last beyond it).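

Moving the fluorine from 3-fluorophenyl to 4-fluorophenyl on the carbonyl carbon leaves the reading level (a 1.0-fold higher number from compound 3 to compound 4 (0.01 log units; within the scatter)). With 4-fluorophenyl, the series also stays within the scatter of both the (piperidin-1-yl)methyl ester (a 1.2-fold higher number from compound 1 to compound 4 (0.07 log units; within the scatter)) and the larger benzotriazole-bearing group (a 1.9-fold lower number from compound 2 to compound 4 (0.28 log units; within the scatter)), so this compound bridges two compounds that differ beyond it. No measurement at hand accounts for this flat response.

The compounds shown leave open whether a phenyl ring carrying an amine or a carboxylic acid on this carbonyl carbon would keep the reading level.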